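Plasma half-life in a diester series: substitution on one aryl ester

The source may report more compounds than this note shows. Statements on the series, on what has been measured and on what is new or still open speak of the compounds shown alone.

Measured so far:
compound 1 `CC(=O)Oc1ccccc1C(=O)O[C@H]1CO[C@H]2[C@@H]1OC[C@H]2OC(=O)c1cccc(O)c1`: 0.0183 h
compound 2 `COc1ccccc1C(=O)O[C@@H]1CO[C@H]2[C@@H]1OC[C@@H]2OC(=O)c1ccccc1OC(C)=O`: 0.0578 h

In an ADME assay on a cell-free system (plasma, Homo sapiens) for metabolic stability, with Plasma (Rattus norvegicus) as the target, read by HPLC, at pH 7.4 (a higher number here means that the compound lasts longer, a lower number that the compound disappears faster), compound 2 stands highest of the two numbers; its nearest neighbour, compound 1, gives 0.0183 h. For the measured compounds named here, the one measured step at the same carbonyl carbon, a 3.2-fold higher number from compound 1 to compound 2 (0.50 log units; beyond the scatter), exchanged the aryl group and gave a modest rise. Compound 3 `CC(=O)Oc1ccccc1C(=O)O[C@H]1CO[C@H]2[C@@H]1OC[C@H]2OC(=O)c1ccc(-c2ccccc2)cc1` carries 4-phenylphenyl in place of 2-methoxyphenyl on a carbonyl carbon. Going by the values given here, only that single step bears on the change, so no direction is firmly indicated; a step of roughly the same size, either way, is expected, a 1.2-fold lower number from compound 2 to compound 3 (0.06 log units; within the scatter). Compound 3 is expected to give 0.05 h, within 0.015 h to 0.17 h.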

Compound 3, half-life: > 0.333 h
Compound 3 was reported as a limit (the forecaster's own chance of this, stated with the estimate: 5%); middle value at least 6.6-fold (0.82 log units) from the limit.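

In this assay, the aryl group on this carbonyl carbon can do more than the modest change seen so far: 4-phenylphenyl gives an at least 5.7-fold higher number from compound 2 to compound 3 (0.76 log units; beyond the scatter) and an at least 18-fold higher number from compound 1 to compound 3 (1.25 log units; beyond the scatter). Both steps are open-ended, as compound 3 sits at a limit of the assay and not at a number: the limit of > 0.333 h in this assay, at which 1 of the 3 values shown sits.

Left open is whether plain phenyl, without the second ring, would keep this half-life, and whether 4-phenylphenyl bearing an amine or a carboxylic acid would. How far compound 3 lies past the limit also remains unread.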